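Replacing 3-Methoxyphenyl with Naphthalen-2-yl on a Shared Core

This account rests on a few compounds, and the source may have more. Where it says the series, first, only, none or still open, it means among the compounds named here.

Compound 1 (`COc1cccc(C(=O)NNC(=O)C2(C(=O)N[C@H]3CC(=O)OC3O)CC2)c1`), compound 2 (`COc1cccc(C(=O)NNC(=O)C2(C(=O)N[C@H]3CC(=O)OC3O)CCC2)c1`) and compound 3 (`COc1cccc(C(=O)NNC(=O)C2(C(=O)N[C@H]3CC(=O)OC3O)CCCC2)c1`) all carry 3-methoxyphenyl and differ only in the core. In a functional assay on THP-1 cells (Homo sapiens) for inhibition (on this read-out higher numbers stand for weaker inhibition and lower numbers for stronger inhibition), compound 1 gives >= 10000 nM as a limit of the assay and not as a number. Compound 2 gives 400 nM and compound 3 gives 550 nM within the usual scatter of each other, so compound 3 stands level with compound 2.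

Compound 4 (`O=C1C[C@H](NC(=O)C2(C(=O)NNC(=O)c3ccc4ccccc4c3)CCCC2)C(O)O1`) keeps the core of compound 3 but has naphthalen-2-yl in place of 3-methoxyphenyl on a carbonyl carbon. Within the data shown here, no measured pair of compounds changes this group, so the data offer no direct guide to its effect. The expectation therefore stays close to compound 3 at 550 nM and leaves wide room in either direction. In this assay the expected step (a 1.2-fold lower number from compound 3 to compound 4 (0.09 log units; within the scatter)) stays within the usual scatter. Compound 4 is estimated at 450 nM (expected range 120 nM to 1800 nM).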

Compound 4, half-maximal inhibitory concentration: 570 nM
Estimate against measurement, compound 4: 1.3-fold (0.10 log units) below; measured number inside the range.
By their numbers in this assay, from the lowest: compounds 2, 3 and 4 (each within the scatter of the next). At a limit, above all of these: compound 1.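

Measured in this assay the change from 3-methoxyphenyl to naphthalen-2-yl on a carbonyl carbon gives a 1.0-fold higher number from compound 3 to compound 4 (0.02 log units; within the scatter) on the core of compound 3. Among these compounds, this is the first look at this position, and it takes a second six-membered aromatic ring and the loss of the only hydrogen-bond acceptor in the group with no change beyond the scatter. For this pair, then, neither the methoxy oxygen nor the single ring is needed to keep this level of inhibition, although nothing shown gives a reason for that.

Still open, from the compounds shown here alone, is whether naphthalen-2-yl behaves the same way on the cores of compound 1 and compound 2. Also open, going by these compounds, is how a group of another kind, such as a carboxylic acid or an amine, would fare on this carbonyl carbon.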